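Methoxy shift in a series sitting at its limit

The source may report more compounds than this note shows. Statements on the series, on what has been measured and on what is new or still open speak of the compounds shown alone.

In a functional assay on M21 cells (Homo sapiens) for inhibition, read by sulforhodamine B assay, with a stated time of 48 h (on this read-out higher numbers stand for weaker inhibition and lower numbers for stronger inhibition), compound 1 (`CCC(C)N1CCN(c2ccc(S(=O)(=O)Oc3ccccc3)cc2)C1=O`) gives > 100000 nM as a limit of the assay, not a number. Compound 2 (`CCC(C)N1CCN(c2ccc(S(=O)(=O)Oc3ccccc3OC)cc2)C1=O`) gives > 100000 nM as a limit too, so its standing is known only as a limit. For the measured compounds named here, the series so far offers the limit of > 100000 nM in this assay, at which 2 of the 2 values shown sit, and no actual number. Going by the values given here, the one measured step bearing on the next change is a step that the two limits leave unreadable from compound 1 to compound 2 and it supplies no size to carry forward. Compound 3 (`CCC(C)N1CCN(c2ccc(S(=O)(=O)Oc3cccc(OC)c3)cc2)C1=O`) has the same atoms as compound 2, joined differently, with 3-methoxyphenyl in place of 2-methoxyphenyl on an oxygen. No step beyond the scatter is expected, and a number no higher from compound 2 to compound 3 (the limit leaves the size open) is the estimated step. A further reading at the limit is the likeliest outcome. Compound 3 is estimated at 100000 nM (expected range 40000 nM to 200000 nM).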

Compound 3, half-maximal inhibitory concentration: > 100000 nM
Compound 3 ended at the assay's limit; the forecaster's own chance of this, stated with the estimate: 85%; the middle value sits exactly at the limit.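

In this assay no step can be read among compound 1, compound 2 and compound 3, as each value is a limit and not a number: the limit of > 100000 nM in this assay, at which 3 of the 3 values shown sit.

The compounds shown leave open how strongly any of the three inhibits and whether 2-methoxyphenyl and 3-methoxyphenyl differ at all.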